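The compounds below may be only part of what the source reports. "The series", "measured", "known", "first", "only" and "open" are said of these compounds alone.

Three compounds have so far been measured in a functional assay on PC-3 cells (Homo sapiens) for antiproliferative activity, read by MTT assay, with a stated time of 48 h; a lower number here means a stronger inhibitor, a higher number a weaker inhibitor:

Compound 1, `C#CC(C)OC(=O)c1ccc(C(CC)(CC)c2ccc(OCCC(O)(CC)CC)c(C)c2)n1CC`, gives 14800 nM.
Compound 2, `C#CCCOC(=O)c1ccc(C(CC)(CC)c2ccc(OCCC(O)(CC)CC)c(C)c2)n1CC`, gives only a limit of the assay, > 50000 nM.
Compound 3, `CCn1c(C(=O)Nc2ccc(OC(F)(F)F)cc2)ccc1C(CC)(CC)c1ccc(OCCC(O)(CC)CC)c(C)c1`, gives only a limit of the assay, > 50000 nM.

Compound 2 therefore does not stand at a number at all: it sits at the limit of this assay, and the limit of > 50000 nM in this assay, at which 2 of the 3 values shown sit, tells that compound 3 sits at the same limit. Among the compounds with values here, the step of an at least 3.3-fold higher number from compound 1 to compound 2 (0.52 log units; beyond the scatter) shows that the only measured change at this oxygen already moved the compound from a number onto the limit. The step of an at least 3.3-fold higher number from compound 1 to compound 3 (0.52 log units; beyond the scatter) shows the same for an amide replacing the ester. The step that the two limits leave unreadable from compound 2 to compound 3 is not readable, since both ends are limits.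

The unmeasured compound 4, `CCn1c(C(=O)NC(CC(=O)O)C(=O)OC)ccc1C(CC)(CC)c1ccc(OCCC(O)(CC)CC)c(C)c1`, differs from compound 2 in one place: a group of 10 heavy atoms (5 carbon, 1 nitrogen, 4 oxygen; no ring) in place of a group of 5 heavy atoms (4 carbon, 1 oxygen; no ring), on a carbonyl carbon. Within the data shown here, the steps that bear on this change, from compound 1 to compound 2 and from compound 1 to compound 3, both ended at the limit, and no measured step departs from it again. Compound 4 is therefore expected to remain at or near the limit, a step that the limit leaves unreadable from compound 2 to compound 4 in this assay. The estimate for compound 4 in this assay is 70000 nM, within a range from 25000 nM to 250000 nM.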

Compound 4, half-maximal inhibitory concentration: 11200 nM
Compound 4: middle estimate off by 6.3-fold (0.80 log units), on the high side; the measured number lies below the stated range.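

In this assay the group on this carbonyl carbon in compound 4 does not hold the series at the limit, as the earlier changes suggested it would: there is an at least 4.4-fold lower number from compound 2 to compound 4 (0.64 log units; beyond the scatter) and also an at least 4.4-fold lower number from compound 3 to compound 4 (0.64 log units; beyond the scatter) on the amide-type nitrogen, so the outcome of an amide here depends on what that nitrogen carries. Against the ester of compound 1 there is a 1.3-fold lower number from compound 1 to compound 4 (0.12 log units; within the scatter), which means that an ester on this carbonyl carbon is not required for a measured number and that a larger group with no ring, in place of the 5 heavy atoms of the esters, can be accepted. Compound 2 remains a limit of the assay and not a number, and so does compound 3: the limit of > 50000 nM in this assay, at which 2 of the 4 values shown sit.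

The compounds shown do not say which part of the new group on the amide-type nitrogen matters, since its two ends were never changed separately. Nor do they say whether an amine or a longer chain at that nitrogen would stay off the limit or would return the series to it.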